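A Urea-Type Link in Place of an Amide

The source may hold more compounds than are shown below. What is called first, only, known or untested is meant among the compounds shown, and "the series" means these compounds.

Of the compounds shown here, two have been measured in a functional assay on SF-295 cells (Homo sapiens) for inhibition, read by sulforhodamine B assay, with a stated time of 48 h; on this read-out lower numbers stand for stronger inhibition of growth and higher numbers for weaker inhibition of growth. Compound 1 `COc1cc(-c2nn(-c3cccc(NC(=O)Nc4cc(C(F)(F)F)cc(C(F)(F)F)c4)c3)cc2-c2ccncc2)ccc1Cl` gives 399 nM in this assay, while compound 2 `COc1cc(-c2nn(-c3cccc(NC(=O)c4cccc(C(F)(F)F)c4)c3)cc2-c2ccncc2)ccc1Cl` gives 1020 nM in this assay, the higher of the two numbers, with the gap to compound 1 beyond the usual scatter. Compound 3 `COc1cc(-c2nn(-c3cccc(NC(=O)Nc4cccc(C(F)(F)F)c4)c3)cc2-c2ccncc2)ccc1Cl` differs from compound 2 by (3-(trifluoromethyl)phenyl)amino in place of 3-(trifluoromethyl)phenyl on a carbonyl carbon. Among the compounds with values here, no measured pair isolates this change, so the expectation leans on compound 1 at 399 nM, which shares the entering linkage. In this assay the expected step is a 1.7-fold lower number from compound 2 to compound 3 (0.23 log units; within the scatter), a moderate move toward a lower number. Compound 3 is expected near 600 nM, within 250 nM to 1500 nM.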

Compound 3, concentration for 50% growth inhibition: 306 nM
For compound 3 the middle estimate is 2.0-fold (0.29 log units) above the measured one; the range from low to high includes it.
By their numbers in this assay, from the lowest: compounds 3 and 1 (each within the scatter of the next); then compound 2.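

In this assay the change from 3-(trifluoromethyl)phenyl to (3-(trifluoromethyl)phenyl)amino on a carbonyl carbon now has its own matched pair, and it gives a 3.3-fold lower number from compound 2 to compound 3 (0.52 log units; beyond the scatter) in a comparison where nothing else differs. Putting hydrogen in place of trifluoromethyl on an aromatic carbon gives a 1.3-fold lower number from compound 1 to compound 3 (0.12 log units; within the scatter) and so leaves the number essentially where it was. Nothing available here gives a reason for either step.

Still open, on these data alone, is whether an amine or a carboxylic acid in place of that trifluoromethyl would keep growth inhibition at this level. Also open, as far as these compounds go, is whether the urea-type link would give a similar step on a different core.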